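Second chloro on the aryl ring of compound 2

A few compounds are considered here, and "the series" means these few. Any claim that something is new, unique, unknown or untested is made for them only; others in the source may bear on it.

Measured compounds:
compound 1, `N#C/C(=C\N1CCN(C(=O)c2ccco2)C1=S)C(=O)c1ccccc1`: 31700 nM
compound 2, `O=CN1CCN(c2ccc(Cl)cc2)C1=S`: 15800 nM

In a functional assay on PC-3 cells (Homo sapiens) for inhibition, read by sulforhodamine B assay, with a stated time of 48 h (a lower number here means a stronger inhibitor of growth, a higher number a weaker inhibitor of growth), compound 2 gives 15800 nM, the lowest of the two numbers available. For the measured compounds named here, its nearest neighbour is compound 1, which in this assay gives 31700 nM; the gap between the two lies within the scatter, so neither can be called the stronger inhibitor of growth on this evidence, and no single structural step links them.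

Compound 3, `O=CN1CCN(c2ccc(Cl)c(Cl)c2)C1=S`, is not yet measured. It differs from compound 2 in one place: chloro in place of hydrogen on an aromatic carbon. Going by the values given here, no step between measured compounds bears on this change, so the expectation rests on compound 2 alone. Among the compounds with values here, a second chloro group on the same ring is a small addition, and no measured pair shows what a chloro group does here; the step from compound 2 to compound 3 is therefore expected to be small, of unknown direction, and most likely within the scatter, as a 1.3-fold lower number from compound 2 to compound 3 (0.12 log units; within the scatter).

For compound 3 the expected value in this assay is 12000 nM, with a range from 4000 nM to 40000 nM.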

Compound 3, concentration for 50% growth inhibition: 14700 nM
The estimate for compound 3 lay 1.2-fold (0.09 log units) below the measured number, and the stated range covers the measured number.
By their numbers in this assay, from the lowest: compounds 3, 2 and 1 (each within the scatter of the next, the first and the last beyond it).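

In this assay, for the compounds shown here, the replacement of hydrogen by chloro gives a 1.1-fold lower number from compound 2 to compound 3 (0.03 log units; within the scatter) and is the first step between measured compounds that differ in one place, so compound 2 and compound 3 cannot be told apart in this read-out. Going by these compounds alone, at this position, an aromatic carbon ortho to a chloro group and meta to a group of 8 heavy atoms, the added chloro therefore brings no change that can be read beyond the scatter, which the earlier compounds could not show because no single step linked them. No measurement given here explains this result.

The compounds shown leave open whether a methoxy group, an amine or a carboxylic acid on this same aromatic carbon would carry the number beyond the scatter, and what the chloro group already present in compound 2 contributes. They also leave open whether a longer chain on the carbonyl of the shared core would matter more than a change on the aryl ring.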